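Removing the tosyl ester from a triazole-bearing core

The source may report more compounds than this note shows. Statements on the series, on what has been measured and on what is new or still open speak of the compounds shown alone.

Compound 1 `C=C1C[C@]23C[C@@]1(O)CC[C@H]2c1ccc(OS(=O)(=O)c2ccc(C)cc2)c(C)c1[C@@H]3Cn1cc(-c2ccc(Cl)cc2)nn1` was assessed in a functional assay on SW480 cells (Homo sapiens) for cytotoxicity, read by MTT assay, with a stated time of 4 days (a lower number here means a stronger inhibitor, a higher number a weaker inhibitor), where compound 1 gives only a limit, > 20000 nM. Compound 2 `C=C1C[C@]23C[C@@]1(O)CC[C@H]2c1ccc(OS(=O)(=O)c2ccc(C)cc2)c(C)c1[C@@H]3Cn1cc(-c2ccc(C)cc2)nn1` likewise returns a limit in this assay, > 20000 nM. Compound 3 `C=C1C[C@]23C[C@@]1(O)CC[C@H]2c1ccc(OS(=O)(=O)c2ccc(C)cc2)c(C)c1[C@@H]3Cn1cc(-c2ccc(F)cc2)nn1` also shows a limit in this assay, > 20000 nM. All three sit at the limit of > 20000 nM in this assay, at which 3 of the 3 values shown sit, so the steps a step that the two limits leave unreadable from compound 1 to compound 2, a step that the two limits leave unreadable from compound 1 to compound 3 and a step that the two limits leave unreadable from compound 2 to compound 3 cannot be sized. Compound 4 `C=C1C[C@]23C[C@@]1(O)CC[C@H]2c1ccc(O)c(C)c1[C@@H]3Cn1cc(-c2ccc(Cl)cc2)nn1` differs from compound 1 by hydrogen in place of (4-methylphenyl)sulfonyl on an oxygen on an aromatic ring. Going by the values given here, no measured step touches that oxygen, and the measured changes, each on an aromatic carbon, all left the values at the limit. Compound 4 is therefore expected to give about 15000 nM in this assay, between 3000 nM and 40000 nM. That estimate means an expected step of an at least 1.3-fold lower number from compound 1 to compound 4 (0.12 log units; that floor lies within the scatter), with a real chance of another limit.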

Compound 4, half-maximal inhibitory concentration: > 20000 nM
Compound 4: no number, only a limit; the forecaster's own chance of this, stated with the estimate: 50%; middle value at least 1.3-fold (0.12 log units) from the limit.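

Going by these compounds alone, compound 4, like compound 1, returns only a limit in this assay, so no step between compound 1 and compound 4 can be read: the limit of > 20000 nM in this assay, at which 4 of the 4 values shown sit. The compounds shown leave open whether hydrogen in place of (4-methylphenyl)sulfonyl changes the value in this assay at all.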